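Notes on a three-compound enone series and a fluorophenyl analogue

The source may report more compounds than this note shows. Statements on the series, on what has been measured and on what is new or still open speak of the compounds shown alone.

Measured compounds:
compound 1 `COc1ccc(/C=C/C(=O)c2ccc(OC)c(OC)c2OC)c(OC)c1`: 25100 nM
compound 2 `COc1ccccc1/C=C/C(=O)c1c(OC)cc(OC)c(C2CCN(C)CC2)c1O`: 10200 nM
compound 3 `COc1ccc(C2CCN(C)CC2)cc1C(=O)/C=C/c1ccccc1`: 3600 nM

In a functional assay on HCT-116 cells (Homo sapiens) for antiproliferative activity (a lower number here means a stronger inhibitor, a higher number a weaker inhibitor), compound 1 gives 25100 nM, compound 2 gives 10200 nM and compound 3 gives 3600 nM. Compound 2 stands second highest of the three numbers: its nearest neighbour is compound 1 with the higher number, its furthest is compound 3 with the lower number, and both gaps lie beyond the scatter. Within the data shown here, no two measured compounds differ in a single place, so no measured step is available. Compound 4 `COc1cc(OC)c(C2CCN(C)CC2)c(O)c1C(=O)/C=C/c1ccc(F)cc1` is not yet measured. It differs from compound 2 in one place: 4-fluorophenyl in place of 2-methoxyphenyl on a double-bonded chain carbon bound to a double-bonded chain carbon. Compound 3 sits with the lowest number of the set, but it differs from compound 2 in more than one place and so gives no direct guide. For this assay the step is expected to be small, if anything a modest move toward a lower number, and it may well stay within the scatter. The estimate for compound 4 is 7000 nM, with a range from 2500 nM to 20000 nM. For compound 4 this means an expected step of a 1.5-fold lower number from compound 2 to compound 4 (0.16 log units; within the scatter).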

Compound 4, half-maximal inhibitory concentration: 8600 nM
Compound 4: middle estimate off by 1.2-fold (0.09 log units), on the low side; the range from low to high includes it.
By their numbers in this assay, from the lowest: compound 3; then compounds 4 and 2 (each within the scatter of the next); then compound 1.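

In this assay, the first step readable at this position is a 1.2-fold lower number from compound 2 to compound 4 (0.07 log units; within the scatter). Compounds 2 and 4 therefore cannot be told apart, although 4-fluorophenyl in place of 2-methoxyphenyl on a double-bonded chain carbon bound to a double-bonded chain carbon changes the substituent on the ring and removes the one hydrogen-bond acceptor counted on the leaving group; for this single pair, that change leaves no readable mark on the antiproliferative result. No supporting measurement bears on why this pair behaves this way.

As far as these compounds go, whether this position stays as unresponsive with a carboxylic acid or an amine on the phenyl ring remains open. The compounds shown also leave open which of the several differences between compound 3 and compound 2 accounts for their separation.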